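The source may report more compounds than this note shows. Statements on the series, on what has been measured and on what is new or still open speak of the compounds shown alone.

Within the data shown here, compound 2, `CC(C)CCOC(=O)NS(=O)(=O)c1sc(CC(C)C)cc1-c1cccc(Cn2ccnc2)c1`, is one of two compounds measured in an assay on HEK293 cells for displacement of a labelled ligand from Type-2 angiotensin II receptor (Homo sapiens), read by scintillation counting, with a stated time of 240 min; a higher number here means a weaker inhibitor, a lower number a stronger inhibitor. In this assay compound 2 gives 230 nM. Among the measured compounds shown here, its only neighbour, compound 1, `CC(C)COC(=O)NS(=O)(=O)c1sc(CC(C)C)cc1-c1cccc(Cn2ccnc2)c1`, gives 130 nM in this assay; the step of a 1.8-fold higher number from compound 1 to compound 2 (0.25 log units; within the scatter) lies within the scatter, so the two numbers cannot be told apart, and compound 2 cannot be called weaker on this evidence.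

Compound 3, `COCCOC(=O)NS(=O)(=O)c1sc(CC(C)C)cc1-c1cccc(Cn2ccnc2)c1`, has not yet been measured. It differs from compound 2 by methoxy in place of isopropyl on a saturated chain carbon, two bonds along the chain from an oxygen next to a carbonyl group. For the measured compounds named here, one measured step touches the same chain: the step of a 1.8-fold higher number from compound 1 to compound 2 (0.25 log units; within the scatter), which lengthened that chain and stayed within the scatter. Going by the values given here, no measured step brings an oxygen into this chain, so the methoxy group enters untested. Because the step of a 1.8-fold higher number from compound 1 to compound 2 (0.25 log units; within the scatter) stayed within the scatter, a change of this chain has so far left the number where it was, and the step of a 1.3-fold higher number from compound 2 to compound 3 (0.12 log units; within the scatter) is expected to be small as well, with a wider range of doubt for the new oxygen. Compound 3 is estimated at 300 nM in this assay, within a range from 110 nM to 850 nM.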

Compound 3, inhibition constant: 480 nM
Beside the measured number, compound 3's estimate is 1.6-fold (0.20 log units) below it, and the stated range covers the measured number.
By their numbers in this assay, from the lowest: compounds 1 and 2 (each within the scatter of the next); then compound 3.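

In this assay, among these compounds, the swap of isopropyl for methoxy gives a 2.1-fold higher number from compound 2 to compound 3 (0.32 log units; beyond the scatter) and is the first change on this chain to move the number beyond the scatter, though only modestly. Compound 1 points the same way, with a 3.7-fold higher number from compound 1 to compound 3 (0.57 log units; beyond the scatter) for methoxymethyl in place of isopropyl, so compound 3 is the weakest of the three, and the chain, which had looked tolerant of change, is not indifferent to every group placed on it. No measurement at hand bears on why the number rises, and the step stands as an observation only.

Methoxy differs from isopropyl both in carrying an oxygen and in having 2 heavy atoms rather than 3, so these three compounds cannot show which of the two differences matters. Going by these compounds, a plain n-butyl chain in place of the 2-methoxyethyl group would help to separate them, while the effect of an amine or a carboxylic acid at this place on the chain, or of a longer chain ending in methoxy, remains open.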